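The compounds below may be only part of what the source reports. "The series", "measured", "known", "first", "only" and "open" are said of these compounds alone.

Among the compounds with values here, compound 1 `CCCc1ccc(NC2=CC(=O)c3nc4n(c3C2=O)[C@H]2OC[C@@H](O)[C@H]2OC4)cc1` is the only member of this small set to give a number rather than a limit: in a functional assay on MGC-803 cells (Homo sapiens) for inhibition, read by sulforhodamine B assay (on this read-out higher numbers stand for weaker inhibition and lower numbers for stronger inhibition), compound 1 gives 1560 nM. Compound 2 `O=C1C(NC2CCCC2)=CC(=O)c2c1nc1n2[C@H]2OC[C@@H](O)[C@H]2OC1` stops at a limit of the assay, > 16000 nM. Compound 3 `O=C1C(N2CCCC2)=CC(=O)c2c1nc1n2[C@H]2OC[C@@H](O)[C@H]2OC1` likewise stops at a limit, > 16000 nM. Within the data shown here, the one measured step, a step that the two limits leave unreadable from compound 2 to compound 3, cannot be read because the limit of > 16000 nM in this assay, at which 2 of the 3 values shown sit, holds both of its values. Compound 4 `Cc1ccc(NC2=CC(=O)c3nc4n(c3C2=O)[C@H]2OC[C@@H](O)[C@H]2OC4)cc1` differs from compound 1 by hydrogen in place of ethyl on a saturated chain carbon bound to an aromatic carbon. Among the measured compounds shown here, no measured step touches this kind of change, so no shift beyond the scatter is expected in either direction. Compound 4 is therefore estimated at 2000 nM, with a range from 800 nM to 6000 nM. This estimate means an expected step of a 1.3-fold higher number from compound 1 to compound 4 (0.11 log units; within the scatter), within the usual scatter.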

Compound 4, half-maximal inhibitory concentration: 1420 nM
Estimate against measurement, compound 4: 1.4-fold (0.15 log units) above; the range from low to high includes it.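

In this assay, within the data shown here, the change from 4-propylphenyl to 4-methylphenyl gives a 1.1-fold lower number from compound 1 to compound 4 (0.04 log units; within the scatter) and this is the first step in the set that can be read. It shows that on a saturated chain carbon bound to an aromatic carbon, propyl and methyl cannot be told apart in this read-out. Nothing shown gives a cause for this step.

The compounds shown cover only propyl and methyl at this place. From the compounds shown here alone, what a longer chain such as hexyl, or a carboxylic acid or an amine there, would do stays open.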